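This account rests on a few compounds, and the source may have more. Where it says the series, first, only, none or still open, it means among the compounds named here.

Compound 1 `CCc1ccccc1-c1nc(N)nc(N)n1` and compound 2 `COc1ccccc1-c1nc(N)nc(N)n1` share a core and differ in a single group on an aromatic carbon. In a functional assay on the whole organism with Rattus norvegicus as the target, at a dose of 20 mg/kg by the intraperitoneal route (a higher number here means more inhibition at the dose given (going by the name of the read-out), a lower number less inhibition), compound 1 gives 20%, while compound 2 gives 1%. Going by the values given here, the one measured step, a number 19 percentage points lower from compound 1 to compound 2 (beyond the scatter), leaves compound 2 with the lower of the two numbers. Compound 3 `Nc1nc(N)nc(-c2ccccc2I)n1`, not yet measured there, differs from compound 2 by iodo in place of methoxy on an aromatic carbon. Among the compounds with values here, no measured step involves iodo, so the step from compound 1 to compound 2 bears on this change only by showing that the group at this carbon can shift the read-out modestly, with methoxy giving the lower value. Compound 3 is therefore expected to land somewhere between the two measured numbers, with an estimated step of a number 9 percentage points higher from compound 2 to compound 3 (within the scatter) that may not clear the scatter. The estimate for compound 3 is 10%, within a range from 0% to 30%.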

Compound 3, a percentage reported as inhibition, in the whole organism at one dose (the size of the read-out at that dose, not a potency) in the Rattus norvegicus assay: -7%
Estimate against measurement, compound 3: 17 percentage points above; the whole stated range lies above it.
By their numbers in the Rattus norvegicus assay, from the lowest: compounds 3 and 2 (each within the scatter of the next); then compound 1.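

Iodo in place of methoxy brings no readable change in the Rattus norvegicus assay, the step being a number 8 percentage points lower from compound 2 to compound 3 (within the scatter), whereas the step from ethyl to iodo reads a number 27 percentage points lower from compound 1 to compound 3 (beyond the scatter), so among these three groups on this aromatic carbon, ethyl alone stands apart. In a physicochemical assay for lipophilicity (a lower number here means a more polar compound, a higher number a more lipophilic compound), compound 2 gives 0.58 and compound 3 gives 1.41. The change to iodo therefore makes the compound clearly more lipophilic without any readable change in inhibition, so across this pair, greater lipophilicity does not bring more inhibition: the measured partition coefficient of compound 2, 0.58, and of compound 3, 1.41, a number 0.83 log units higher (beyond the scatter)

From the compounds shown here alone, whether the higher number seen with ethyl belongs to a small carbon chain at this position remains open. A propyl group or an amino group on the same carbon would speak to that question.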